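Changing the benzyl group on a weakly cytotoxic sulfonyl guanidine

This account rests on a few compounds, and the source may have more. Where it says the series, first, only, none or still open, it means among the compounds named here.

Compound 1 `Cc1cc(S(=O)(=O)/N=C(\N)n2nccc2-c2ccccc2)c(SCc2ccc(Cl)cc2)cc1Cl`: 75000 nM
Compound 2 `Cc1cc(-c2ccccc2)n(/C(N)=N/S(=O)(=O)c2cc(C)c(Cl)cc2SCc2cccc(C(F)(F)F)c2)n1`: 41000 nM

Of the compounds shown here, two have been tested in a functional assay on MCF7 cells (Homo sapiens) for cytotoxicity, read by MTT assay, with a stated time of 72 h; on this read-out lower numbers stand for stronger inhibition and higher numbers for weaker inhibition. There compound 1 gives 75000 nM, which stands highest of the two numbers, although its gap to compound 2, which gives 41000 nM, lies within the usual scatter, so the two cannot be told apart. Compound 3 `Cc1cc(S(=O)(=O)/N=C(\N)n2nccc2-c2ccccc2)c(SCc2ccccc2C(F)(F)F)cc1Cl` is not yet measured. It differs from compound 1 in one place: 2-(trifluoromethyl)phenyl in place of 4-chlorophenyl on a saturated chain carbon bound to a sulfur. Going by the values given here, no pair of measured compounds shows this change on its own, so its size cannot be read from the data. Both measured compounds sit at weak inhibition, and the change keeps one six-membered aromatic ring of carbon only in the same place, so for compound 3 the step of a 1.3-fold lower number from compound 1 to compound 3 (0.10 log units; within the scatter) is expected to stay within the scatter, in no clear direction. Compound 3 is therefore estimated at 60000 nM, with a range from 25000 nM to 150000 nM.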

Compound 3, half-maximal inhibitory concentration: 21000 nM
Compound 3: middle estimate off by 2.9-fold (0.46 log units), on the high side, and the stated range ends above it.
By their numbers in this assay, from the lowest: compounds 3, 2 and 1 (each within the scatter of the next, the first and the last beyond it).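

In this assay the exchange of 4-chlorophenyl for 2-(trifluoromethyl)phenyl on a saturated chain carbon bound to a sulfur gives a 3.6-fold lower number from compound 1 to compound 3 (0.55 log units; beyond the scatter). This is the first single change shown at this position, and it shows that the number responds to the group placed there, a response the earlier compounds could not isolate. The step is modest, and compound 3 at 21000 nM remains a weak inhibitor, while nothing measured here accounts for the change.

From the compounds shown here alone, whether the lower number goes with the trifluoromethyl group itself or with where it sits on the ring stays open, as this single step alters both at once. Also open, going by these compounds, is how the position would respond to an amine or a carboxylic acid in place of 2-(trifluoromethyl)phenyl.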